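The compounds below may be only part of what the source reports. "The series", "measured", "known", "first", "only" and "open" are said of these compounds alone.

Of the compounds shown here, three built on one shared core have been measured in a functional assay on HeLa cells (Homo sapiens) for antiproliferative activity, read by CCK-8 assay, with a stated time of 72 h, tested at 2 uM; on this read-out higher numbers stand for a stronger effect at the one concentration tested and lower numbers for a weaker effect. Compound 1 `Nc1ccccc1NC(=O)c1ccc(CSC(=S)N2CCCc3ccccc32)cc1` gives 26.1%. Compound 2 `Nc1ccccc1NC(=O)c1ccc(CSC(=S)N2CCc3cc(Cl)ccc32)cc1` gives 40.1%. Compound 3 `CC1CCCCN1C(=S)SCc1ccc(C(=O)Nc2ccccc2N)cc1` gives 45.5%, the highest of the three numbers shown, although one of its two steps lies within the scatter, a number 5.4 percentage points higher from compound 2 to compound 3 (within the scatter), and only the other lies beyond it, a number 19.4 percentage points higher from compound 1 to compound 3 (beyond the scatter).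

Compound 4 `CN1CCN(C(=S)SCc2ccc(C(=O)Nc3ccccc3N)cc2)CC1` differs from compound 3 in one place: 4-methylpiperazin-1-yl in place of 2-methylpiperidin-1-yl on a thiocarbonyl carbon. Every measured step bears on the same position, the nitrogen substituent on the thiocarbonyl carbon: a number 14 percentage points higher from compound 1 to compound 2 (beyond the scatter), a number 19.4 percentage points higher from compound 1 to compound 3 (beyond the scatter) and a number 5.4 percentage points higher from compound 2 to compound 3 (within the scatter). For the measured compounds named here, both fused bicyclic amines gave lower numbers than the 2-methylpiperidin-1-yl of compound 3, but no measured pair sets one saturated six-membered ring against another, so the exchange for 4-methylpiperazin-1-yl has no direct precedent. Given that the ring size and heavy-atom count are kept, the expected step is one that stays within the scatter, a number 5.5 percentage points lower from compound 3 to compound 4 (within the scatter), with a slight lean downward. For compound 4 the estimated value in this assay is 40%, with a range from 25% to 55%.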

Compound 4, a percentage reported as inhibition, at one concentration (the size of the read-out at that concentration, not a potency): 52.6%
For compound 4 the middle estimate is 12.6 percentage points below the measured one; low and high end bracket the measured number.
By their numbers in this assay, from the lowest: compound 1; then compounds 2, 3 and 4 (each within the scatter of the next, the first and the last beyond it).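

Exchanging 2-methylpiperidin-1-yl for 4-methylpiperazin-1-yl on the thiocarbonyl carbon gives a number 7.1 percentage points higher from compound 3 to compound 4 (within the scatter) in this assay, so in this first comparison of two saturated six-membered rings, a ring with 2 hetero atoms in place of one with 1 hetero atom leaves the read-out within the scatter. Compound 4 also stands clear of both fused bicyclic amines, with a number 12.5 percentage points higher from compound 2 to compound 4 (beyond the scatter) and a number 26.5 percentage points higher from compound 1 to compound 4 (beyond the scatter), whereas the step to compound 3 from compound 2 stayed within the scatter, so the separation from the chloro-substituted amine appears only with the 4-methylpiperazin-1-yl group. Nothing in hand accounts for these differences at this position.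

The compounds shown leave open which feature of the 4-methylpiperazin-1-yl group matters, since neither an unsubstituted piperazin-1-yl, a 4-ethylpiperazin-1-yl nor a morpholin-4-yl group stands among them to separate the ring nitrogen from its methyl group. With a single concentration in this assay, they also leave open whether the order seen here would hold for potency.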